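This account rests on a few compounds, and the source may have more. Where it says the series, first, only, none or still open, it means among the compounds named here.

Of the compounds shown here, three bearing a shared core have been measured in an assay on isolated protein for inhibition of Indoleamine 2,3-dioxygenase 1 (Homo sapiens), read by spectrophotometry; on this read-out lower numbers stand for stronger inhibition and higher numbers for weaker inhibition. Compound 1 `COc1ccc2[nH]c(C(=O)Cc3cccnc3)cc2c1` gives 49000 nM in this assay. Compound 2 `O=C(Cc1cccnc1)c1cc2cc(F)ccc2[nH]1` differs from compound 1 by fluoro in place of methoxy on an aromatic carbon, and in this assay compound 2 gives 36000 nM. This change made a 1.4-fold lower number from compound 1 to compound 2 (0.13 log units; within the scatter). Compound 3 `COc1cccc2[nH]c(C(=O)Cc3cccnc3)cc12` is built from the same atoms as compound 1, joined differently; the difference between the two cores is not broken down here. In this assay compound 3 gives 58000 nM, which sits within the scatter of compound 1 and of compound 2.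

Compound 4 `O=C(Cc1cccnc1)c1cc2c(F)cccc2[nH]1` has not yet been measured. It differs from compound 3 by fluoro in place of methoxy on an aromatic carbon. This is the same kind of change as that from compound 1 to compound 2, but the place is not identical: in compound 2 the fluoro sits meta to a fused ring and para to a fused ring, whereas in compound 4 it sits ortho to a fused ring and meta to a fused ring. Because the same kind of change gave a 1.4-fold lower number from compound 1 to compound 2 (0.13 log units; within the scatter), the step from compound 3 to compound 4 in this assay is expected to be a 1.4-fold lower number from compound 3 to compound 4 (0.14 log units; within the scatter). Compound 4 is therefore estimated at 42000 nM in this assay, with a likely range from 20000 nM to 90000 nM.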

Compound 4, half-maximal inhibitory concentration: 153000 nM
Compound 4: the middle estimate sits 3.6-fold (0.56 log units) below what was measured; the measured number lies above the stated range.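

In this assay, fluoro in place of methoxy on the core of compound 3 gave a 2.6-fold higher number from compound 3 to compound 4 (0.42 log units; beyond the scatter), a step beyond the scatter, and so it did not repeat what the same kind of change had done on the core of compound 1. Set side by side, the two steps differ: the same change on two cores in this assay, a 1.4-fold lower number (0.13 log units; within the scatter) from compound 1 to compound 2 and a 2.6-fold higher number (0.42 log units; beyond the scatter) from compound 3 to compound 4, 3.6-fold (0.56 log units) apart, beyond the scatter of two such steps. This shows that, in this series, the size and direction of the step on one core did not carry over to the other, with the fluoro of compound 4 ortho to a fused ring and meta to a fused ring; it does not show why the steps part, and two pairs give no rule for any further core.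

The compounds shown carry only methoxy or fluoro at these places, so it stays open how a chloro, a nitrile or an amine would behave there in this assay. From the compounds shown here alone, whether a hydroxyl or a trifluoromethyl in place of methoxy would also give different steps on the two cores is equally open.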